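Two Chlorines in Place of One Fluorine

The source may report more compounds than this note shows. Statements on the series, on what has been measured and on what is new or still open speak of the compounds shown alone.

Compound 1 `COc1cc(C(=O)N/N=C/c2cccc(F)c2)cc(OC)c1OC` was tested in a functional assay on PC-3 cells (Homo sapiens) for antiproliferative activity, read by MTT assay, tested at 1 uM (a higher number here means a stronger effect of the compound at the concentration tested, a lower number a weaker effect), where compound 1 gives 53.5%. Among the three compounds measured so far, compound 1 stands highest. Its nearest neighbour is compound 2 `COc1cc(C(=O)N/N=C/c2cccc(C(F)(F)F)c2)cc(OC)c1OC`, which gives 51%; the step of a number 2.5 percentage points lower from compound 1 to compound 2 (within the scatter) is within the scatter, so the two cannot be told apart. Compound 3 `COc1cc(C2=NN(C(C)=O)C(c3ccccc3F)O2)cc(OC)c1OC`, built on a different framework, gives 13.5%, far below compound 1.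

Compound 4 `COc1cc(C(=O)N/N=C/c2cc(Cl)cc(Cl)c2)cc(OC)c1OC` has not yet been measured. It differs from compound 1 in one place: 3,5-dichlorophenyl in place of 3-fluorophenyl on a carbon with a double bond to nitrogen. Among the compounds with values here, the only measured step that touches the same ring, trifluoromethyl in place of fluoro, was a number 2.5 percentage points lower from compound 1 to compound 2 (within the scatter) and stayed within the scatter. Within the data shown here, no measured pair shows chlorine or a second substituent on that ring, so the measured steps bear only loosely on this change. A step beyond the scatter in this assay is therefore not expected. Compound 4 is estimated at 55%, between 40% and 70%. The expected step of a number 1.5 percentage points higher from compound 1 to compound 4 (within the scatter) is thus taken to lie within the scatter.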

Compound 4, a percentage reported as inhibition, at one concentration (the size of the read-out at that concentration, not a potency): 22.1%
For compound 4 the middle estimate is 32.9 percentage points above the measured one; the whole stated range lies above it.
By their numbers in this assay, from the lowest: compounds 3 and 4 (each within the scatter of the next); then compounds 2 and 1 (each within the scatter of the next).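

The exchange of 3-fluorophenyl for 3,5-dichlorophenyl on the carbon with a double bond to nitrogen gives a number 31.4 percentage points lower from compound 1 to compound 4 (beyond the scatter) in this assay. Within the data shown here, the only earlier step on this ring, trifluoromethyl in place of fluoro, was a number 2.5 percentage points lower from compound 1 to compound 2 (within the scatter), so the read-out here had not yet been seen to respond to a change on this ring, and this change shows that it can respond strongly. Nothing available explains this loss of effect.

The change brings in chlorine and a second substituent on the ring together, and the compounds shown do not separate the two. Going by these compounds, how a ring carrying an amine or a carboxylic acid would behave in this assay also stays open.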